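Trifluoromethyl on the aryl piperazine of indane ether amines

A few compounds are considered here, and "the series" means these few. Any claim that something is new, unique, unknown or untested is made for them only; others in the source may bear on it.

Measured in a functional assay on the whole organism for inhibition, with Mus musculus as the target, at a dose of 25 mg/kg by the oral route; on this read-out higher numbers stand for more inhibition at the one dose given (going by the name of the read-out) and lower numbers for less inhibition:
compound 1 `c1ccc(N2CCN(CCCCCOc3ccc4c(c3)CCC4)CC2)cc1` gives 25%
compound 2 `Clc1ccc(N2CCN(CCCCOc3ccc4c(c3)CCC4)CC2)cc1` gives 33%
compound 3 `FC(F)(F)c1cccc(N2CCN(CCCOc3ccc4c(c3)CCC4)CC2)c1` gives 73%

Compound 1 carries an unsubstituted phenyl on the piperazine and a five-carbon chain to the indane ether. Among the three numbers in this assay compound 1 stands lowest. Compound 2 lies closest to it, and the gap between the two is within the scatter of this read-out, so no order between compound 1 and compound 2 can be read from them. Compound 3 lies furthest from compound 1, beyond the scatter, but compound 3 differs from compound 1 in more than one place, so the gap cannot be assigned to any single change.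

Compound 4 `FC(F)(F)c1cccc(N2CCN(CCCCCOc3ccc4c(c3)CCC4)CC2)c1` keeps the five-carbon chain and the core of compound 1 and differs from compound 1 only in one change: trifluoromethyl in place of hydrogen on an aromatic carbon. Among the compounds with values here, no measured pair isolates this change, so the size of the step rests on judgement. Given that compound 3, the only measured compound bearing trifluoromethyl, gives 73%, a step upward in this assay from compound 1 is expected, larger than the scatter and held short of the number for compound 3. The step is estimated as a number 30 percentage points higher from compound 1 to compound 4 (beyond the scatter). For compound 4 the estimate in this assay is 55%, expected to fall between 30% and 80%.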

Compound 4, a percentage reported as inhibition, in the whole organism at one dose (the size of the read-out at that dose, not a potency): 66%
Compound 4: the middle estimate sits 11 percentage points below what was measured, within the range that was stated.
By their numbers in this assay, from the lowest: compounds 1 and 2 (each within the scatter of the next); then compounds 4 and 3 (each within the scatter of the next).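

In this assay, the change from phenyl to 3-(trifluoromethyl)phenyl gives a step of a number 41 percentage points higher from compound 1 to compound 4 (beyond the scatter), and this first matched pair in the series ties a large gain to trifluoromethyl on this aromatic carbon, meta to a large group, with the five-carbon chain and the core held fixed. Compound 3 at 73% and compound 4 at 66% lie within the scatter of each other, so these two values give no order between the two chain lengths when trifluoromethyl is present. Nothing in hand bears on the reason for the step.

Within the data shown here, still open is whether the step belongs to trifluoromethyl itself or would also appear with a nitrile, a methoxy group or a chlorine on the same aromatic carbon, since compound 2, the only other substituted compound, differs from compound 1 in more than one place. Also open, as far as these compounds go, is how a longer chain, or trifluoromethyl on another carbon of the same ring, would read at this one dose.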